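Replacing Cyclohexyl with 4-Methoxyphenyl on a Shared Core

The compounds below may be only part of what the source reports. "The series", "measured", "known", "first", "only" and "open" are said of these compounds alone.

Of the compounds shown here, three have been measured in a physicochemical assay for solubility, with a stated time of 18 h, at pH 7.4; a higher number here means a more soluble compound, a lower number a less soluble compound. Compound 1 `COc1ccc(F)cc1CNCCCNc1ccnc2cc(C3CCCCC3)ccc12` gives 4200 nM. Compound 3 `COc1cccc(CNCCCNc2ccnc3cc(Cc4ccc(C#N)cc4)ccc23)c1O` gives 4200 nM, level with compound 1 at the digits shown, and together the two sit at the lower end of the three numbers. Compound 2 `Fc1ccc(Oc2ccc3c(NCCCNCc4ccco4)ccnc3c2)cc1` gives 14500 nM, the highest number of the set. Among the compounds with values here, no step between compounds differing in one place is available.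

Compound 4 `COc1ccc(-c2ccc3c(NCCCNCc4cc(F)ccc4OC)ccnc3c2)cc1` is not yet measured. It differs from compound 1 by 4-methoxyphenyl in place of cyclohexyl on an aromatic carbon. Without a matched step to draw on, the expectation for compound 4 is a change of about a 1.2-fold higher number from compound 1 to compound 4 (0.08 log units; within the scatter), within the scatter. Compound 4 is estimated at 5000 nM in this assay, with a range from 1500 nM to 16000 nM.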

Compound 4, solubility: 32000 nM
Compound 4: the middle estimate sits 6.4-fold (0.81 log units) below what was measured, and the stated range ends below it.
By their numbers in this assay, from the lowest: compounds 1 and 3 (each within the scatter of the next); then compound 2; then compound 4.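

In this assay, within the data shown here, 4-methoxyphenyl in place of cyclohexyl on this aromatic carbon gives a 7.6-fold higher number from compound 1 to compound 4 (0.88 log units; beyond the scatter), a step beyond the scatter and the first matched step in the set. It shows that the number is not indifferent to which of these two groups sits at this position on the shared core. No measured evidence bears on why the number moves.

A single step cannot separate the exchange of ring from the added methoxy group, and a plain phenyl at this carbon would address that. As far as these compounds go, whether a morpholine here would give a similar number remains open.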